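Replacing a carbamate side chain on an aziridinylquinone core

A few compounds are considered here, and "the series" means these few. Any claim that something is new, unique, unknown or untested is made for them only; others in the source may bear on it.

Compound 1 `CC1=C(N2CC2)C(=O)C(CC(C)OC(N)=O)=C(N2CC2)C1=O` carries two aziridin-1-yl groups on a quinone core, one methyl and a longer chain ending in a carbamate. In a functional assay on L1210 cells (Mus musculus), with a stated time of 12 days (a lower number here means a less potent compound, a higher number a more potent compound, by a factor of ten per unit of this negative logarithm), compound 1 gives 5.79, the highest of the three measured values. Compound 3 `CCC1=C(N2CC2)C(=O)C(CC)=C(N2CC2)C1=O`, with two ethyl groups, gives 5.09, lower by a gap beyond the scatter, and compound 2 `CCCC1=C(N2CC2)C(=O)C(CCC)=C(N2CC2)C1=O`, with two propyl groups, gives 4.44, further below. Among the measured compounds shown here, compound 4 `COC(CO)C1=C(N2CC2)C(=O)C(C)=C(N2CC2)C1=O` differs from compound 1 as follows: a group of 5 heavy atoms (3 carbon, 2 oxygen; no ring) in place of a group of 7 heavy atoms (4 carbon, 1 nitrogen, 2 oxygen; no ring), on a double-bonded ring carbon No measured pair shows this change, so the estimate rests on compound 1 alone. Compound 4 is expected to give 5.5, within a range from 4.9 to 6.1. This estimate means an expected step of a number 0.29 log units lower from compound 1 to compound 4 (within the scatter), a small decrease that may still lie within the scatter.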

Compound 4, logarithm of the reciprocal of the active concentration, log(1/C): 5.75
Compound 4: the middle estimate sits 0.25 log units below what was measured, and the stated range covers the measured number.
By their numbers in this assay, from the lowest: compound 2; then compound 3; then compounds 4 and 1 (each within the scatter of the next).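

Swapping the carbamate-ending chain for 2-hydroxy-1-methoxyethyl on this double-bonded ring carbon gives a number 0.04 log units lower from compound 1 to compound 4 (within the scatter), so the two compounds stand level within the scatter. Among the compounds shown here, this is the first comparison to isolate this one position, and it shows that the smaller group, with the same printed counts of hydrogen-bond donors and acceptors, matches the larger one here. Nothing shown explains this match.

The compounds shown leave open how an amine or a carboxylic acid would read in this place. A longer chain ending in a hydroxyl group also remains an open case.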